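This account rests on a few compounds, and the source may have more. Where it says the series, first, only, none or still open, it means among the compounds named here.

Compound 1 `Cn1c(/C=C2\SC(=O)N(CC(=O)N3CCOCC3)C2=O)nc2ccccc21`: 38500 nM
Compound 2 `CCn1c(/C=C2\SC(=O)N(CC(=O)N3CCOCC3)C2=O)nc2ccccc21`: > 50000 nM (a limit of the assay)

For the measured compounds named here, in a functional assay on A549 cells (Homo sapiens) for inhibition, read by MTT assay, with a stated time of 48 h (a higher number here means a weaker inhibitor, a lower number a stronger inhibitor), compound 1 gives 38500 nM, the only exact number so far. Compound 2 gives > 50000 nM, which is a limit of the assay and not a number. Compound 3 `CC1CN(C(=O)CN2C(=O)S/C(=C\c3nc4ccccc4n3C)C2=O)CC(C)O1` keeps the core of compound 1 but carries a different group on a carbonyl carbon: 2,6-dimethylmorpholin-4-yl in place of morpholin-4-yl on a carbonyl carbon. Going by the values given here, the only measured step, an at least 1.2-fold higher number from compound 1 to compound 2 (0.11 log units; that floor lies within the scatter), lies at a different place and stays within the scatter, so no step beyond the scatter is expected here. The expected change is a 1.0-fold higher number from compound 1 to compound 3 (0.02 log units; within the scatter). The estimated value for compound 3 is 40000 nM, with an expected range of 15000 nM to 50000 nM.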

Compound 3, half-maximal inhibitory concentration: 29400 nM
Estimate against measurement, compound 3: 1.4-fold (0.13 log units) above; measured number inside the range.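

In this assay, replacing morpholin-4-yl with 2,6-dimethylmorpholin-4-yl on the carbonyl carbon gives a 1.3-fold lower number from compound 1 to compound 3 (0.12 log units; within the scatter). For the compounds shown here, this is the first view of this position, and a group with 8 heavy atoms in place of 6 leaves the number unchanged within the scatter. The change therefore shows no measurable gain or loss of activity in these cells.

From the compounds shown here alone, whether piperazin-1-yl or a diethylamino group on this carbonyl carbon would move the number beyond the scatter stays open. Compound 2 also gives only a limit of the assay, not a number: the limit of > 50000 nM in this assay, at which 1 of the 3 values shown sits.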